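The source may report more compounds than this note shows. Statements on the series, on what has been measured and on what is new or still open speak of the compounds shown alone.

Of the compounds shown here, two carry numbers so far. Compound 1 `CCCOCCNC1=Nc2ccccc2C(C)N1` gives in an assay on isolated protein for binding affinity to 5-hydroxytryptamine receptor 5A (Homo sapiens) (on this read-out lower numbers stand for stronger inhibition and higher numbers for weaker inhibition), a value of 241 nM. Compound 2 `CCCNC1=Nc2ccccc2C(C)N1` gives in this assay a value of 153 nM. Among the compounds with values here, the single step between them, a 1.6-fold lower number from compound 1 to compound 2 (0.20 log units; within the scatter), puts methyl in place of propoxy on a saturated chain carbon, two bonds along the chain from an amine nitrogen. Compound 2 therefore stands beside compound 1 rather than apart from it, and the two numbers allow no ranking.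

Compound 3 `CCCCNC1=Nc2ccccc2C(C)N1` is still to be measured in this assay. It differs from compound 2 by methyl in place of hydrogen on a saturated chain carbon, three bonds along the chain from an amine nitrogen, the chain reading propyl to butyl. Within the data shown here, the only measured step, a 1.6-fold lower number from compound 1 to compound 2 (0.20 log units; within the scatter), removed a propoxy group and shortened the chain, so it bears on the present change only loosely, and it was itself within the scatter. Nothing seen so far suggests that one added methyl should move the number beyond the scatter. The expected step of a 1.0-fold lower number from compound 2 to compound 3 (0.01 log units; within the scatter) is accordingly small and of uncertain direction. Compound 3 is estimated at 150 nM, with a range from 60 nM to 400 nM.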

Compound 3, inhibition constant in the 5-hydroxytryptamine receptor 5A assay: 189 nM
Beside the measured number, compound 3's estimate is 1.3-fold (0.10 log units) below it; the range from low to high includes it.
By their numbers in the 5-hydroxytryptamine receptor 5A assay, from the lowest: compounds 2, 3 and 1 (each within the scatter of the next).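

In the 5-hydroxytryptamine receptor 5A assay, the propyl to butyl change, three bonds along the chain from an amine nitrogen, reads as a 1.2-fold higher number from compound 2 to compound 3 (0.09 log units; within the scatter), and the ethyl in place of propoxy comparison reads as a 1.3-fold lower number from compound 1 to compound 3 (0.11 log units; within the scatter), so compounds 1, 2 and 3 still allow no ranking and this position has so far tolerated all three chains. Within the data shown here, the same propyl to butyl change does register in a physicochemical assay for lipophilicity (on this read-out higher numbers stand for higher lipophilicity and lower numbers for lower lipophilicity), as a number 0.50 log units higher from compound 2 to compound 3 (beyond the scatter), which is something the earlier compounds did not show. In the physicochemical assay compound 2 gives -0.8 and compound 3 gives -0.3 on this read-out. At this position, then, the added methyl separates the two compounds on lipophilicity while their receptor numbers in the 5-hydroxytryptamine receptor 5A assay stay within the scatter of each other, as the values in the physicochemical assay show: the measured distribution coefficient of compound 2, -0.8, and of compound 3, -0.3, a number 0.50 log units higher (beyond the scatter)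

Going by these compounds, whether a longer chain such as pentyl, or a branched chain such as isobutyl, would give a step beyond the scatter in the 5-hydroxytryptamine receptor 5A assay remains open. Also open, on these data alone, is whether a hydroxyl, an amine or a carboxylic acid on this chain would separate from compounds 1, 2 and 3 in that assay.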